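Methoxy for Methyl on Two Anilines of a Shared Core

The source may hold more compounds than are shown below. What is called first, only, known or untested is meant among the compounds shown, and "the series" means these compounds.

Compound 1 `COc1ccc(-c2ccnc(Nc3ccc(Cl)cc3Cl)n2)cc1`, compound 2 `Cc1ccc(-c2ccnc(Nc3ccc(Cl)cc3Cl)n2)cc1` and compound 3 `Cc1cccc(Nc2nccc(-c3ccc(Cl)cc3Cl)n2)c1` were examined in a functional assay on HeLa cells (Homo sapiens) for antiproliferative activity, read by MTT assay; on this read-out lower numbers stand for stronger inhibition and higher numbers for weaker inhibition. Compound 1 gave 23000 nM, compound 2 gave 91500 nM and compound 3 gave 7660 nM, the lowest of the three. Between compound 2 and compound 1 the change is methoxy in place of methyl on an aromatic carbon, and it produced a 4.0-fold lower number from compound 2 to compound 1 (0.60 log units; beyond the scatter). Compound 3 and compound 2 contain the same atoms joined differently; the difference between the two cores is not broken down here.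

Compound 4 `COc1cccc(Nc2nccc(-c3ccc(Cl)cc3Cl)n2)c1` has not yet been measured. It differs from compound 3 by methoxy in place of methyl on an aromatic carbon. Among the compounds with values here, this is the same kind of change as the one from compound 2 to compound 1, not the same: there the group entered para to a large group, here it enters meta to a large group. Compound 4 is expected to show a 2.6-fold lower number from compound 3 to compound 4 (0.41 log units; beyond the scatter) in this assay, an expectation that rests on the earlier step of a 4.0-fold lower number from compound 2 to compound 1 (0.60 log units; beyond the scatter). That earlier step occurred at a different place, which tempers the expectation. The estimate for compound 4 in this assay is 3000 nM, with a range from 1000 nM to 9000 nM.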

Compound 4, half-maximal inhibitory concentration: 76400 nM
Compound 4: middle estimate off by 25-fold (1.41 log units), on the low side; measured number above the stated range.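

In this assay the swap of methyl for methoxy on the core of compound 3 gave a 10-fold higher number from compound 3 to compound 4 (1.00 log units; beyond the scatter) and so ran opposite to the earlier step. The two steps differ in direction and by more than the scatter allows: the same change on two cores in this assay, a 4.0-fold lower number (0.60 log units; beyond the scatter) from compound 2 to compound 1 and a 10-fold higher number (1.00 log units; beyond the scatter) from compound 3 to compound 4, 40-fold (1.60 log units) apart, beyond the scatter of two such steps. Within the data shown here, this shows that the result of this change on one core was no guide to its result on the other, but with only one pair on each core it does not show why the steps part, nor whether the core or the place of the group is responsible.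

The compounds shown leave open whether methoxy placed meta to a large group on the core of compound 1 would raise or lower the number. They also leave open whether another group at this place, such as an amine or a carboxylic acid, would follow either of the two steps.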